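A few compounds are considered here, and "the series" means these few. Any claim that something is new, unique, unknown or untested is made for them only; others in the source may bear on it.

Compound 1 `Cc1ccc(Cc2cn3cc(Cl)ccc3nc2=O)cc1`: > 1000000 nM
Compound 2 `CC1(C)OC2O[C@@H](Cc3cn4ccccc4nc3=O)C(OCc3ccccc3)C2O1`: > 1000000 nM

Both compounds were tested in a functional assay on HeLa cells (Homo sapiens) for cytotoxicity, read by MTT assay, with a stated time of 24 h; on this read-out lower numbers stand for stronger inhibition and higher numbers for weaker inhibition. In this assay compound 1 gives > 1000000 nM. That reading is a limit of the assay and not a number, so compound 1 has no exact potency to start from. Compound 2 gives > 1000000 nM, which is a limit too. The two compounds therefore share one reading, (the limit of > 1000000 nM in this assay, at which 2 of the 2 values shown sit), and neither can be ranked against the other.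

Compound 3 `O=c1nc2ccc(Cl)cn2cc1Cc1ccc([N+](=O)[O-])cc1` keeps the core of compound 1 and changes one group: nitro in place of methyl on an aromatic carbon. Put simply, compound 3 carries a nitro where compound 1 carries a methyl, para to a large group.

Among the measured compounds shown here, no measured pair shows what this swap does. The expectation rests only on compound 1, whose reading of > 1000000 nM is again a limit. In this assay no step beyond the usual scatter is expected, and another limit is the likeliest result. The expected change is a number no higher from compound 1 to compound 3 (the limit leaves the size open). The estimate for compound 3 is 1000000 nM, with an expected range of 200000 nM to 2000000 nM.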

Compound 3, half-maximal inhibitory concentration: 928000 nM
For compound 3 the middle estimate is 1.1-fold (0.03 log units) above the measured one; low and high end bracket the measured number.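

Among the compounds shown here, compound 3 is the first compound here with a reading that is a number and not a limit: in this assay compound 3 gives 928000 nM. As far as these compounds go, compound 1 gives > 1000000 nM, which is a limit and not a number, so the true size of the swap stays unknown. With nitro in place of methyl on this aromatic carbon, para to a large group, the result is an at least 1.0-fold lower number from compound 1 to compound 3 (0.03 log units; that floor lies within the scatter), which shows only that a measurable reading can be obtained with nitro at this position, while most readings still rest at one limit and leave little to rank the compounds by: the limit of > 1000000 nM in this assay, at which 2 of the 3 values shown sit.

From the compounds shown here alone, what stays open is whether another group at this same position, such as an amine, a carboxylic acid or a longer chain, would bring the number down by a step that stands clear of the usual scatter. Also open, going by these compounds, is how the rest of the structure contributes, since compound 2 differs from compound 1 in more than one place and offers no clean comparison with either of the other two compounds.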